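This account rests on a few compounds, and the source may have more. Where it says the series, first, only, none or still open, it means among the compounds named here.

Measured in an ADME assay on microsomes from liver (Mus musculus) for metabolic stability, read by LC-MS, using NADPH, tested at 1 uM; a higher number here means that the compound lasts longer, a lower number that the compound disappears faster:
- compound 1 `Nc1nc(-c2cc(Cl)cc(C(F)(F)F)c2)c(C(=O)c2ccccc2Cl)s1`: 0.102 h
- compound 2 `Nc1nc(-c2cc(Br)cc(C(F)(F)F)c2)c(C(=O)c2ccccc2Cl)s1`: 0.0867 h

Within the scatter of compound 1, compound 2 stands at 0.0867 h. Compound 3 `COc1ccccc1C(=O)c1sc(N)nc1-c1cc(Br)cc(C(F)(F)F)c1` has not been measured yet. It differs from compound 2 by methoxy in place of chloro on an aromatic carbon, ortho to a large group. For the measured compounds named here, the only measured step, a 1.2-fold lower number from compound 1 to compound 2 (0.07 log units; within the scatter), is a small one and is a different change, bromo in place of chloro, made elsewhere in the molecule. It gives no direct guide to this replacement, and no direction can be drawn from it. No step beyond the scatter is expected in this assay, only an estimated 1.2-fold lower number from compound 2 to compound 3 (0.06 log units; within the scatter). The estimated half-life of compound 3 is 0.075 h, with an expected range of 0.035 h to 0.16 h.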

Compound 3, half-life: 0.0383 h
Estimate against measurement, compound 3: 2.0-fold (0.29 log units) above; the measured number falls inside the stated range.
By their numbers in this assay, from the lowest: compound 3; then compounds 2 and 1 (each within the scatter of the next).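

In this assay, for the compounds shown here, the change from 2-chlorophenyl to 2-methoxyphenyl gives a 2.3-fold lower number from compound 2 to compound 3 (0.35 log units; beyond the scatter) and is the first step beyond the scatter. This position, ortho to a large group, therefore affects the half-life, and methoxy is the less favourable of the two groups tested there. Nothing available accounts for this step.
Going by these compounds, whether an amine, a nitrile or a longer chain such as ethoxy at this position would give a longer or shorter half-life remains open. Also open, on these data alone, is whether the methoxy step holds on the core of compound 1.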